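One aryl group exchanged: from compound 2 to compound 3

A few compounds are considered here, and "the series" means these few. Any claim that something is new, unique, unknown or untested is made for them only; others in the source may bear on it.

Going by the values given here, compound 2 `C=CCn1c(=O)/c(=C\c2cc(F)ccc2C)[nH]c(=O)/c1=C\c1ccccc1OC` is the only member of this small set with a number to its name: in a functional assay on Huh-7 cells (Homo sapiens) for cytotoxicity, read by CCK-8 assay, with a stated time of 72 h (a higher number here means a weaker inhibitor, a lower number a stronger inhibitor), compound 2 gives 5600 nM. Its companion, compound 1 `C=CCn1c(=O)/c(=C\c2ccc(C)cc2)[nH]c(=O)/c1=C\c1ccccc1OC`, is reported in this assay only as "not active" (no number reported), so compound 2 stands alone on the scale, with nothing above or below it to compare against. Compound 3 `C=CCn1c(=O)/c(=C\c2ccccc2F)[nH]c(=O)/c1=C\c1ccccc1OC` has not yet been measured in this assay. It differs from compound 2 in one place: 2-fluorophenyl in place of 5-fluoro-2-methylphenyl on a double-bonded chain carbon bound to an aromatic carbon. Among the compounds with values here, no step between two measured compounds is available to gauge the size of such a change. Since compound 1, which carries a different aryl group, is reported as "not active" (no number reported), a weakening is considered more likely than a gain, and the step of a 1.6-fold higher number from compound 2 to compound 3 (0.21 log units; within the scatter) is expected to be modest, possibly reaching beyond the scatter. Compound 3 is therefore expected to give about 9000 nM in this assay, within a range of 3000 nM to 30000 nM.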

Compound 3, half-maximal inhibitory concentration: 31300 nM
Compound 3: middle estimate off by 3.5-fold (0.54 log units), on the low side; measured number above the stated range.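

In this assay, replacing 5-fluoro-2-methylphenyl with 2-fluorophenyl on the double-bonded chain carbon bound to an aromatic carbon gives a 5.6-fold higher number from compound 2 to compound 3 (0.75 log units; beyond the scatter) and provides the first measured size for a change at this place. The place is therefore sensitive to the aryl group, even when a group of 7 heavy atoms replaces one of 8 and both groups keep their fluorine, yet compound 3 still gives a number, while compound 1 is reported as "not active" (no number reported) in the same assay. No measurement shown gives a reason for this step.

From the compounds shown here alone, the change alters the methyl and the fluorine pattern together, so the share of each stays open, and a compound with 2-methylphenyl at this place would help separate them. Also open, going by these compounds, is how this place would respond to an aryl group bearing an amine or a carboxylic acid.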